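The compounds below may be only part of what the source reports. "The series", "measured", "known", "first", "only" and "open" are said of these compounds alone.

Of the compounds shown here, three built on one shared core have been measured in a functional assay on HEK293 cells for agonist activity at Glucose-dependent insulinotropic receptor (Homo sapiens), read by a luciferase reporter; a lower number here means that less compound is needed, a higher number that more compound is needed for the effect. Compound 1 `CC#CCn1c(N2CCC[C@@H](N)C2)nc2c1c(=O)n(CCCN1CCN(c3ncc(F)cn3)CC1)c(=O)n2C` gives 1410 nM. Compound 2 `CC#CCn1c(N2CCC[C@@H](N)C2)nc2c1c(=O)n(CCCN1CCC(c3nc(-c4ccccc4)c[nH]3)CC1)c(=O)n2C` gives 600 nM, and compound 3 `CC#CCn1c(N2CCC[C@@H](N)C2)nc2c1c(=O)n(CCCN1CCC(c3nc(-c4ccccc4)cs3)CC1)c(=O)n2C` gives 3130 nM. Compound 1 thus stands second highest of the three numbers: compound 3 is the nearest to it, and compound 2, with the lowest number of the three, lies furthest from it. Among the compounds with values here, the only step between measured compounds that differ in a single place is a 5.2-fold higher number from compound 2 to compound 3 (0.72 log units; beyond the scatter); it concerns the group on the saturated ring carbon and leaves the rest of the molecule untouched.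

Compound 4 `CC#CCn1c(N2CCC[C@@H](N)C2)nc2c1c(=O)n(CCCN1CCN(c3ncc(C(F)(F)F)cn3)CC1)c(=O)n2C` differs from compound 1 in one place: trifluoromethyl in place of fluoro on an aromatic carbon. Within the data shown here, no measured step bears on this exchange. Among the measured compounds shown here, compounds 2 and 3 vary a different part of the molecule, and nothing among the measured compounds shows what swapping the group on the six-membered aromatic ring with 2 nitrogen does. The expectation for compound 4 therefore rests on compound 1 alone, and the step of a 1.0-fold lower number from compound 1 to compound 4 (0.00 log units; within the scatter) is expected to stay within the scatter, in either direction. Compound 4 is estimated at 1400 nM, within a range from 500 nM to 4000 nM.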

Compound 4, half-maximal effective concentration: 4020 nM
The estimate for compound 4 lay 2.9-fold (0.46 log units) below the measured number; measured number outside the range, above it.
By their numbers in this assay, from the lowest: compound 2; then compound 1; then compounds 3 and 4 (each within the scatter of the next).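

In this assay, the carbon para to a large group on the six-membered aromatic ring with 2 nitrogen proves sensitive to what it carries: trifluoromethyl in place of fluoro gives a 2.9-fold higher number from compound 1 to compound 4 (0.46 log units; beyond the scatter). Within the data shown here, this is the first reading at this position, since the earlier single-place step concerned only the group on the saturated ring carbon. The exchange adds heavy atoms, 4 in place of 1, but leaves the counts of hydrogen-bond donors and acceptors and the net charge unchanged, and no measurement shown here explains why the number rises.

Among these compounds, with only two groups compared at this carbon, it remains open whether the number follows the size of the group or some other feature of it. Hydrogen, a methyl group, a chlorine atom, a nitrile or an amine at the same carbon would help to separate these possibilities, and would show whether any group there brings the number below that of the fluoro compound.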